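This account rests on a few compounds, and the source may have more. Where it says the series, first, only, none or still open, it means among the compounds named here.

Compound 1 `Cc1cc(-c2ccc(O)cc2)c2ncc(CSCCc3ccccc3)n2c1` carries a 4-hydroxyphenyl on its core, and in an ADME assay on HEL cells (Homo sapiens) for cytotoxicity, with a stated time of 3 days (a higher number here means that more compound is tolerated, a lower number that less compound is tolerated), compound 1 gives 13.7 ug/mL. Compound 2 `Cc1cc(-c2ccccc2)c2ncc(CSCCc3ccccc3)n2c1` differs from it only by a hydrogen in place of the hydroxy on an aromatic carbon, and in this assay compound 2 gives 33 ug/mL; the step is a 2.4-fold higher number from compound 1 to compound 2 (0.38 log units; beyond the scatter). Compound 3 `Cc1cc(-c2ccc(O)cc2)cn2c(CSCCc3ccccc3)cnc12` is built from the same atoms as compound 1, joined into a differently arranged core. In this assay compound 3 reaches only a limit, > 50 ug/mL, so no number is known for it, as recorded in the limit of > 50 ug/mL in this assay, at which 1 of the 3 values shown sits. Compound 4 `Cc1cc(-c2cccc(O)c2)cn2c(CSCCc3ccccc3)cnc12` has not yet been measured in this assay; (3-hydroxyphenyl in place of 4-hydroxyphenyl on an aromatic carbon). Among the compounds with values here, no measured step moves the hydroxy from one position of the phenyl ring to another: the only step on record, a 2.4-fold higher number from compound 1 to compound 2 (0.38 log units; beyond the scatter), removes the hydroxy altogether, and it does so on the core shared by compounds 1 and 2 rather than on the core of compound 3. With compound 3 standing at a limit, the step to compound 4 can only be framed as an expectation. The number for compound 4 is expected to stay near the limit reached by compound 3, with a number no higher from compound 3 to compound 4 (the limit leaves the size open) expected to fall within the scatter. Compound 4 is therefore estimated at 50 ug/mL, with a range from 25 ug/mL to 100 ug/mL.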

Compound 4, half-maximal cytotoxic concentration: 50 ug/mL
Compound 4: middle estimate and measured number agree at the digits printed, within the range that was stated.
By their numbers in this assay, from the lowest: compound 1; then compounds 2 and 4 (each within the scatter of the next).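

In this assay compound 4 gives 50 ug/mL as an actual number on the core it shares with compound 3, carrying 3-hydroxyphenyl on the aromatic carbon where compound 3 carries 4-hydroxyphenyl. For compound 3 the value > 50 ug/mL remains a limit and not a number. Moving the hydroxy around the phenyl ring therefore gives a number no higher from compound 3 to compound 4 (the limit leaves the size open) and, although this is the first step on record that changes the hydroxy's position rather than removing it, its size cannot be read because one end of the step is a limit: the limit of > 50 ug/mL in this assay, at which 1 of the 4 values shown sits.

The compounds shown leave open what the hydroxy contributes on this core, since its removal is recorded only on the core of compounds 1 and 2, and a plain phenyl at this place on the core of compounds 3 and 4 would be needed to say so. They also leave open how a methoxy, an amine or a carboxylic acid in place of the hydroxy on the phenyl ring would read in this assay on either core.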